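From Fluoro to Chloro on a Shared Core

This account rests on a few compounds, and the source may have more. Where it says the series, first, only, none or still open, it means among the compounds named here.

Compound 1 `O=C1C(=O)N(CCCCn2cc(COc3cc(=O)oc4ccccc34)nn2)c2ccc(F)cc21` was examined in a functional assay on HCT-116 cells (Homo sapiens) for inhibition, read by sulforhodamine B assay, with a stated time of 48 h, tested at 50 uM (on this read-out lower numbers stand for less inhibition of growth and higher numbers for more inhibition of growth at the one concentration tested), where compound 1 gives 67%. This is the lowest of the two numbers recorded so far. Its nearest neighbour is compound 2 `O=C1C(=O)N(CCCn2cc(COc3cc(=O)oc4ccccc34)nn2)c2ccc(F)cc21`, which in this assay gives 75%, a value that lies within the usual scatter of compound 1, so the two cannot be separated. Compound 3 `O=C1C(=O)N(CCCCn2cc(COc3cc(=O)oc4ccccc34)nn2)c2ccc(Cl)cc21` has not yet been measured. It differs from compound 1 in one place: chloro in place of fluoro on an aromatic carbon. Within the data shown here, no step between two measured compounds bears directly on this change, so the outlook rests on the two values alone and on the change itself. Because compound 1 gives 67% in this assay and compound 2 gives 75% there, the present account expects chloro in place of fluoro to produce no step beyond the scatter. The estimated step of a number 3 percentage points higher from compound 1 to compound 3 (within the scatter) is accordingly expected to be small. Compound 3 is therefore expected to give about 70% in this assay, with a range from 50% to 88%.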

Compound 3, percent growth inhibition at one concentration: 62%
The estimate for compound 3 lay 8 percentage points above the measured number; measured number inside the range.
By their numbers in this assay, from the lowest: compounds 3, 1 and 2 (each within the scatter of the next, the first and the last beyond it).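

In this assay, among these compounds, the exchange of chloro for fluoro on an aromatic carbon of the shared core gives a number 5 percentage points lower from compound 1 to compound 3 (within the scatter), the first direct reading of a change at this position. On this six-membered aromatic ring of carbon only, at the place meta to a fused ring and para to a fused ring, the two halogens cannot be separated on this read-out, and substantial inhibition of growth remains with either one at the single concentration tested. No measurement at hand offers an explanation for this result, so the reading stops at the values themselves.

The compounds shown leave open how this position would respond to a group that is not a halogen, such as a methoxy group, an amine or a carboxylic acid, or to plain hydrogen in place of the halogen. They also leave open whether chloro would give the same reading on the chain of compound 2 or on a longer chain, and how these single-concentration numbers would translate into a full concentration response.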